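Urea to amide in a pyrazole series: activity percentages

A few compounds are considered here, and "the series" means these few. Any claim that something is new, unique, unknown or untested is made for them only; others in the source may bear on it.

For the measured compounds named here, compound 2 `COc1cc(Cl)cc(-c2nn(-c3cccc(NC(=O)Nc4cccc(C(F)(F)F)c4)c3)cc2-c2ccncc2)c1` was tested in a functional assay on MOLT-4 cells (Homo sapiens) for inhibition, read by sulforhodamine B assay, with a stated time of 48 h, tested at 0.01 uM (a higher number here means a weaker effect of the compound at the concentration tested, a lower number a stronger effect), and gives 95%, the lower of the two numbers so far. Going by the values given here, its nearest neighbour, compound 1 `COc1cc(Cl)cc(-c2nn(-c3cccc(NC(=O)Nc4ccc(Cl)c(C(F)(F)F)c4)c3)cc2-c2ccncc2)c1`, gives 99% in this assay; the only measured step, a number 4 percentage points lower from compound 1 to compound 2 (within the scatter), concerns hydrogen in place of chloro on an aromatic carbon and stays within the scatter. Compound 3 `COc1cc(Cl)cc(-c2nn(-c3cccc(NC(=O)c4cccc(C(F)(F)F)c4)c3)cc2-c2ccncc2)c1` is not yet measured in this assay. It differs from compound 2 by 3-(trifluoromethyl)phenyl in place of (3-(trifluoromethyl)phenyl)amino on a carbonyl carbon. Among the compounds with values here, no measured step touches the carbonyl carbon or its amide-type nitrogen, so the one step in hand gives no guide of its own to this change beyond showing that a small change elsewhere left the read-out unmoved. With both measured compounds at the weak end of the scale, compound 3 is expected to give a similar number, an estimated 95% with a range of 82% to 104%, so that the expected step of no change at the digits printed from compound 2 to compound 3 (within the scatter) does not clearly exceed the scatter.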

Compound 3, a percentage reported as activity, at one concentration (the size of the read-out at that concentration, not a potency): 91%
Estimate against measurement, compound 3: 4 percentage points above; the range from low to high includes it.
By their numbers in this assay, from the lowest: compounds 3, 2 and 1 (each within the scatter of the next).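

In this assay, the carbonyl carbon now has a measured step: 3-(trifluoromethyl)phenyl in place of (3-(trifluoromethyl)phenyl)amino gives a number 4 percentage points lower from compound 2 to compound 3 (within the scatter), so at this concentration the amide does not separate from the urea. With 3-(trifluoromethyl)phenyl in place of (4-chloro-3-(trifluoromethyl)phenyl)amino, the result is a number 8 percentage points lower from compound 1 to compound 3 (within the scatter), so the read-out also does not separate these two compounds. Nothing available explains this flat result.

All three compounds lie at the weak end of the scale at a single low concentration, so these numbers cannot show whether the urea and the amide would differ at higher concentrations. Also open, going by these compounds, is what a piperidine ring or a butyl chain on the same carbonyl carbon would give in place of the aromatic group.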